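The source may hold more compounds than are shown below. What is called first, only, known or untested is meant among the compounds shown, and "the series" means these compounds.

Measured in an ADME assay on HCT-116 cells (Homo sapiens) for cytotoxicity, read by CellTiter-Glo, with a stated time of 72 h (a higher number here means a weaker inhibitor, a lower number a stronger inhibitor), each value being a limit of the assay and not a number:

Compound 1 `Cc1noc(C)c1S(=O)(=O)N1CCC(N2CCC(C)CC2)CC1`: > 10000 nM
Compound 2 `COc1ccccc1-c1cccc(S(=O)(=O)N2CCC(N3CCC(C)CC3)CC2)c1`: > 5000 nM
Compound 3 `CC1CCN(C2CCN(S(=O)(=O)c3cccc(-c4ccccc4F)c3)CC2)CC1`: > 5000 nM

Compound 3 stands only at a limit, > 5000 nM, so it has no exact value. Compound 4 `Cc1cccc(S(=O)(=O)N2CCC(N3CCC(C)CC3)CC2)c1` has methyl in place of 2-fluorophenyl on an aromatic carbon. Going by the values given here, the only measured step is a step that the two limits leave unreadable from compound 2 to compound 3, so it offers no size to carry over. Compound 1 , which has no phenyl group on its aromatic ring, also stands at a limit, > 10000 nM. Nothing here points to a gain in strength in this assay, so no change beyond the usual scatter is expected. The expected step is a step that the limit leaves unreadable from compound 3 to compound 4 in size. For compound 4 the estimate is 8000 nM, with an expected range from 4000 nM to 20000 nM.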

Compound 4, half-maximal inhibitory concentration: > 5000 nM
Compound 4 ended at the assay's limit; the forecaster's own chance of this, stated with the estimate: 90%; the middle value does not contradict the limit.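

Going by these compounds alone, no step from compound 1, compound 2 or compound 3 to compound 4 can be read: all four values are limits in this assay, not numbers. The compounds shown leave open how strong each one actually is, and whether any of these group changes alters that.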